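The compounds below may be only part of what the source reports. "The series", "measured", "known", "first", "only" and "open" are said of these compounds alone.

Four compounds that share one core are compared in a functional assay on HT-29 cells (Homo sapiens) for cytotoxicity, read by MTT assay, with a stated time of 24 h; a lower number here means a stronger inhibitor, a higher number a weaker inhibitor. Compound 1 `Cc1ccc2oc(-c3ccc(NC(=O)CN4CCN(CCN(C)C)CC4)c(C)c3)nc2c1` gives 7240 nM in this assay. Compound 2 `Cc1cc(-c2nc3cc(Cl)ccc3o2)ccc1NC(=O)CN1CCN(CCN(C)C)CC1` gives 13200 nM in this assay. The two differ by methyl in place of chloro on an aromatic carbon, and the step between them is a 1.8-fold lower number from compound 2 to compound 1 (0.26 log units; within the scatter). Compound 3 `Cc1cc(-c2nc3cc(Cl)ccc3o2)ccc1NC(=O)CCl` carries a different side chain on the same core; the difference between the cores of compound 2 and compound 3 is not broken down here. In this assay compound 3 gives only a limit of the assay, > 100000 nM. That reading sits at the limit of > 100000 nM in this assay, at which 1 of the 3 values shown sits.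

Compound 4 `Cc1ccc2oc(-c3ccc(NC(=O)CCl)c(C)c3)nc2c1` has not yet been measured in this assay. Among the measured compounds shown here, it differs from compound 3 by methyl in place of chloro on an aromatic carbon, which is the same change, at the same place on the core, as the one that turns compound 2 into compound 1. The measured version of this change moved the number only a little, and compound 3 starts from a limit rather than from a number. The step is therefore expected to be a step that the limit leaves unreadable from compound 3 to compound 4, since its measured counterpart was a 1.8-fold lower number from compound 2 to compound 1 (0.26 log units; within the scatter) and compound 3 rests at the limit of > 100000 nM in this assay, at which 1 of the 3 values shown sits. In this assay compound 4 is expected to give roughly 150000 nM, with a likely range from 50000 nM to 450000 nM, and it is quite possible that the assay again reports only a limit.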

Compound 4, half-maximal inhibitory concentration: 13800 nM
Beside the measured number, compound 4's estimate is 11-fold (1.04 log units) above it; the measured number lies below the stated range.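

In this assay, methyl in place of chloro on an aromatic carbon does not give one step of the same size on both cores, and the two steps lie further apart than the scatter allows: the same change on two cores in this assay, a 1.8-fold lower number (0.26 log units; within the scatter) from compound 2 to compound 1 and an at least 7.2-fold lower number (0.86 log units; beyond the scatter) from compound 3 to compound 4, at least 3.9-fold (0.59 log units) apart, beyond the scatter of two such steps

On the core of compound 3 the change gives an at least 7.2-fold lower number from compound 3 to compound 4 (0.86 log units; beyond the scatter), yet that step starts from a reading that is a limit of the assay and not a number, so only a lower bound on its size can be stated: the limit of > 100000 nM in this assay, at which 1 of the 4 values shown sits.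

What the pair of steps shows is that, in this series, the size of the step seen on one core could not be carried over to the other, although the direction is shared only as far as the first step, which stays within the scatter, allows. It does not show what sets the two steps apart, and two pairs of compounds give no rule for any further core.

The compounds shown leave open how the same change would read on a core with a side chain ending in a morpholine, a simple primary amine or a longer carbon chain. They also leave open whether a group other than methyl or chloro, such as fluoro or methoxy, at the same aromatic carbon would follow either step.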